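The source may hold more compounds than are shown below. What is called first, only, known or untested is meant among the compounds shown, and "the series" means these compounds.

Among the compounds with values here, in a functional assay on HL-60 cells (Homo sapiens) for inhibition, read by MTT assay, with a stated time of 48 h (on this read-out lower numbers stand for stronger inhibition of growth and higher numbers for weaker inhibition of growth), compound 3 `CN1CC[C@H](c2c(O)cc(O)c3c(=O)cc(/C=C/c4c(F)c(F)c(F)c(F)c4F)oc23)[C@H](O)C1`, which carries a 2,3,4,5,6-pentafluorophenyl group, gives 3000 nM, the lowest of the three numbers measured so far. Compound 1 `CN1CC[C@H](c2c(O)cc(O)c3c(=O)cc(/C=C/c4ccc(Cl)cc4)oc23)[C@H](O)C1`, with 4-chlorophenyl instead, gives 8000 nM, and compound 2 `CN1CC[C@H](c2c(O)cc(O)c3c(=O)cc(/C=C/c4cccc(Cl)c4)oc23)[C@H](O)C1`, with 3-chlorophenyl, gives 20000 nM.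

Compound 4 `CN1CC[C@H](c2c(O)cc(O)c3c(=O)cc(/C=C/c4ccccc4Cl)oc23)[C@H](O)C1` has not yet been measured. It has 2-chlorophenyl in place of 2,3,4,5,6-pentafluorophenyl on a double-bonded chain carbon bound to a double-bonded chain carbon.

Two measured steps compare a chlorophenyl with pentafluorophenyl directly: a 2.7-fold lower number from compound 1 to compound 3 (0.43 log units; beyond the scatter) and a 6.7-fold lower number from compound 2 to compound 3 (0.82 log units; beyond the scatter). Both favour pentafluorophenyl, so the reverse swap should raise the number. Within the data shown here, the two chlorophenyl compounds also differ from each other, a 2.5-fold higher number from compound 1 to compound 2 (0.40 log units; beyond the scatter), and no 2-chlorophenyl compound has a measured value, so the size of the step remains uncertain.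

In this assay the expected result is a 3.7-fold higher number from compound 3 to compound 4 (0.56 log units; beyond the scatter). For compound 4 the estimated value is 11000 nM, with an expected range of 4500 nM to 27000 nM.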

Compound 4, concentration for 50% growth inhibition: 9000 nM
The estimate for compound 4 lay 1.2-fold (0.09 log units) above the measured number; the measured number falls inside the stated range.
By their numbers in this assay, from the lowest: compound 3; then compounds 1 and 4 (each within the scatter of the next); then compound 2.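

In this assay, 2-chlorophenyl completes the set of chlorophenyl groups on the double-bonded chain carbon, and the place of the chlorine does not give a steady trend. The 2-chlorophenyl and 4-chlorophenyl groups cannot be told apart, with a 1.1-fold higher number from compound 1 to compound 4 (0.05 log units; within the scatter), whereas 3-chlorophenyl is set apart by a 2.2-fold lower number from compound 2 to compound 4 (0.35 log units; beyond the scatter). Pentafluorophenyl keeps its lead over all three chlorophenyl groups, now including a 3.0-fold higher number from compound 3 to compound 4 (0.48 log units; beyond the scatter), so at this position the lowest number shown belongs to the ring carrying fluorine rather than to any chlorine placement.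

As far as these compounds go, how a 4-fluorophenyl, 4-methoxyphenyl or 4-aminophenyl group would compare here stays open, and with it whether the lead of pentafluorophenyl belongs to fluorine itself. No measurement at hand explains these differences.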